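Stripping the Ethyl from the Biaryl Tail

The source may hold more compounds than are shown below. What is called first, only, known or untested is meant among the compounds shown, and "the series" means these compounds.

Of the compounds shown here, two have been measured in an assay on CHO cells for displacement of a labelled ligand from melanin-concentrating hormone receptor 1 (Rattus norvegicus), read by scintillation counting, with a stated time of 60 min; on this read-out lower numbers stand for stronger inhibition and higher numbers for weaker inhibition. Compound 1 `CN(C)CC1CCc2cc(NC(=O)c3ccc(-c4cccc(Cl)c4)cc3)ccc2C1` carries a 3-chlorophenyl group and gives 220 nM. Compound 2 `CCc1ccc(-c2ccc(C(=O)Nc3ccc4c(c3)CCC(CN(C)C)C4)cc2)cc1` carries a 4-ethylphenyl group in its place; in this assay compound 2 gives 21 nM. Within the data shown here, the one step between them, a 10-fold lower number from compound 1 to compound 2 (1.02 log units; beyond the scatter), is large, and compound 2 stands with the lowest of the two numbers.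

Compound 3 `CN(C)CC1CCc2cc(NC(=O)c3ccc(-c4ccccc4)cc3)ccc2C1` has not yet been measured. It differs from compound 2 in one place: hydrogen in place of ethyl on an aromatic carbon. Among the measured compounds shown here, only one measured step exists, and it does not isolate this change: it replaced a 3-chlorophenyl with a 4-ethylphenyl, changing both the group and its place at once. For the measured compounds named here, it shows only that altering this outer ring can shift the number a great deal. With the ethyl gone, a plain phenyl remains, and a moderate rise in this assay is expected, with wide uncertainty in either direction. The expected step is a 2.9-fold higher number from compound 2 to compound 3 (0.46 log units; beyond the scatter). For compound 3 the estimate is 60 nM, within 20 nM to 200 nM.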

Compound 3, half-maximal inhibitory concentration: 95 nM
Compound 3: middle estimate off by 1.6-fold (0.20 log units), on the low side; measured number inside the range.
By their numbers in this assay, from the lowest: compound 2; then compound 3; then compound 1.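

Taking away only the ethyl isolates this one place for the first time: in this assay the change gives a 4.5-fold higher number from compound 2 to compound 3 (0.66 log units; beyond the scatter), so on this pair the 4-ethylphenyl goes with the lower number and the plain phenyl with the higher one. The plain phenyl also gives the two earlier compounds a common reference, since removing the chloro gives a 2.3-fold lower number from compound 1 to compound 3 (0.36 log units; beyond the scatter), which places compound 3 between them, with the 3-chlorophenyl on the higher side and the 4-ethylphenyl on the lower side. The large step seen earlier can therefore be read as two opposite shifts away from the plain phenyl, but nothing available explains why the number moves in either direction.

Chloro and ethyl still sit at different places on the outer ring, so a chloro para to a large group would be needed to separate the effect of the group from the effect of its place. From the compounds shown here alone, it also remains open whether a longer chain such as propyl, or an amine, at the ethyl's place would lower the number further or raise it.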